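A few compounds are considered here, and "the series" means these few. Any claim that something is new, unique, unknown or untested is made for them only; others in the source may bear on it.

Among the measured compounds shown here, compound 1 `CC(C)(C)OC(=O)NCC1CCCN(C(=O)CN2CN(c3ccccc3)C3(CCN(C(=O)c4ccc(C5CCCCC5)cc4)CC3)C2=O)C1` is one of three compounds measured in an assay on HEK293 cells for displacement of a labelled ligand from NPC1-like intracellular cholesterol transporter 1 (Homo sapiens) (on this read-out lower numbers stand for stronger inhibition and higher numbers for weaker inhibition), where compound 1 gives 3800 nM. Among these three it holds the second highest number. Compound 2 `CS(=O)(=O)NCCNC(=O)CN1CN(c2ccccc2)C2(CCN(C(=O)c3ccc(C4CCCCC4)cc3)CC2)C1=O` gives 2100 nM in this assay, a gap to compound 1 that lies within the usual scatter. Compound 3 `CC(C)(C)OC(=O)NCC1CCCN(C(=O)CN2CN(c3ccccc3)C3(CCN(C(=O)c4ccc(C(C)(C)C)cc4)CC3)C2=O)C1` gives 9500 nM, and the change from cyclohexyl to tert-butyl on the aromatic carbon brings a 2.5-fold higher number from compound 1 to compound 3 (0.40 log units; beyond the scatter).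

Compound 4 `CC(C)(C)OC(=O)NC1CCCN(C(=O)CN2CN(c3ccccc3)C3(CCN(C(=O)c4ccc(C5CCCCC5)cc4)CC3)C2=O)C1` differs from compound 1 in another part of the molecule: (tert-butoxycarbonyl)amino in place of ((tert-butoxycarbonyl)amino)methyl on a saturated ring carbon. For the measured compounds named here, no measured step touches this part, so the only known step gives no direct guide; a shift beyond the scatter in either direction is not expected. Compound 4 is therefore expected to give about 4000 nM in this assay, with a plausible range from 1500 nM to 11000 nM, which means an expected step of a 1.1-fold higher number from compound 1 to compound 4 (0.02 log units; within the scatter).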

Compound 4, half-maximal inhibitory concentration: 4400 nM
Compound 4: middle estimate off by 1.1-fold (0.04 log units), on the low side; measured number inside the range.
By their numbers in this assay, from the lowest: compounds 2, 1 and 4 (each within the scatter of the next, the first and the last beyond it); then compound 3.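

On the saturated ring carbon two ring bonds from the ring nitrogen, putting (tert-butoxycarbonyl)amino in place of ((tert-butoxycarbonyl)amino)methyl gives a 1.2-fold higher number from compound 1 to compound 4 (0.06 log units; within the scatter) in this assay, so these two groups cannot be told apart on this read-out. Among the compounds shown here, this is the first reading at this position, and it holds only for this pair of groups on the core of compound 1. No measured evidence bears on why the two groups read alike. On these data alone, it remains open whether a free amine, a carboxylic acid or a longer chain at this carbon would also stay within the scatter of compound 1.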